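This account rests on a few compounds, and the source may have more. Where it says the series, first, only, none or still open, it means among the compounds named here.

Measured in an ADME assay (liver) for metabolic stability, with Liver microsome (Rattus norvegicus) as the target, using microsomes and NADPH, with a stated time of 30 min, at 37 degrees C, tested at 1 uM; on this read-out higher numbers stand for fast clearance and lower numbers for slow clearance:
- compound 1 `CC(C)Nc1nc(S(=O)(=O)c2ccc(N)nc2)ccc1-c1ccc(C(C)(O)C(F)(F)F)cn1`: 62 mL.min-1.g-1
- compound 2 `CC(O)(c1ccc(-c2ccc(S(=O)(=O)c3ccc(N)nc3)nc2NC2CCCCC2)nc1)C(F)(F)F`: 280 mL.min-1.g-1
- compound 3 `CC(O)(c1ccc(-c2ccc(S(=O)(=O)c3ccc(N)nc3)nc2Nc2ccccc2)nc1)C(F)(F)F`: 100 mL.min-1.g-1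

Compound 3 gives 100 mL.min-1.g-1, which lies within the scatter of compound 1 and clearly under compound 2. Compound 4 `CC(O)(c1ccc(-c2ccc(S(=O)(=O)c3ccc(N)nc3)nc2Nc2ccccn2)nc1)C(F)(F)F` has pyridin-2-yl in place of phenyl on a nitrogen on an aromatic ring.

For the measured compounds named here, no measured step makes this exact swap, so the closest evidence comes from other changes at the same nitrogen. Isopropyl to phenyl gave a 1.6-fold higher number from compound 1 to compound 3 (0.21 log units; within the scatter), and cyclohexyl to phenyl gave a 2.8-fold lower number from compound 2 to compound 3 (0.45 log units; beyond the scatter). Isopropyl to cyclohexyl gave a 4.5-fold higher number from compound 1 to compound 2 (0.65 log units; beyond the scatter). These steps are modest at most, and each one replaces a group of a different kind. Here, one six-membered aromatic ring replaces another, so a smaller step seems likely, though the data cannot show its direction. The expected change is a 1.3-fold lower number from compound 3 to compound 4 (0.10 log units; within the scatter), which would not stand beyond the scatter. For compound 4 the estimated value is 80 mL.min-1.g-1, with an expected range from 35 mL.min-1.g-1 to 170 mL.min-1.g-1.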

Compound 4, intrinsic clearance in microsomes: 130 mL.min-1.g-1
Compound 4: the middle estimate sits 1.6-fold (0.21 log units) below what was measured; measured number inside the range.
By their numbers in this assay, from the lowest: compounds 1, 3 and 4 (each within the scatter of the next, the first and the last beyond it); then compound 2.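

In this assay, swapping a ring carbon of the aromatic group on this nitrogen for a ring nitrogen gives no change that can be told from the scatter (the step is a 1.3-fold higher number from compound 3 to compound 4 (0.11 log units; within the scatter)), so at this position pyridin-2-yl and phenyl cannot be told apart. Pyridin-2-yl also stays clearly away from cyclohexyl (a 2.2-fold lower number from compound 2 to compound 4 (0.33 log units; beyond the scatter)), and, unlike phenyl, it stands beyond the scatter from isopropyl (a 2.1-fold higher number from compound 1 to compound 4 (0.32 log units; beyond the scatter)), though both of these steps are modest. No measurement shown here offers an explanation for these numbers.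

Still open, as far as these compounds go, is whether the place of the ring nitrogen matters, as pyridin-3-yl or pyridin-4-yl would show. Also open, from the compounds shown here alone, is how a ring with a second nitrogen, such as pyrimidin-2-yl, or a saturated ring holding oxygen, such as tetrahydropyran-4-yl, would read in this assay.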